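This account rests on a few compounds, and the source may have more. Where it says the series, first, only, none or still open, it means among the compounds named here.

Working notes on the series.

The shared core of compound 1, `CC(=O)OC(C)n1cnc2c(Cl)nc(N)nc21`, carries an acetyl-bearing side chain on a ring nitrogen. In a functional assay on CCRF-CEM cells (Homo sapiens) for inhibition (on this read-out lower numbers stand for stronger inhibition and higher numbers for weaker inhibition), compound 1 gives > 500000 nM. That value is a limit of the assay and not a number; (the limit of > 500000 nM in this assay, at which 1 of the 3 values shown sits). Compound 2, `CC(=O)OC(C)n1cnc2c(Cl)nc(I)nc21`, differs from compound 1 only by iodo in place of amino on an aromatic carbon, and in this assay compound 2 gives 15900 nM. That change gives an at least 31-fold lower number from compound 1 to compound 2 (1.49 log units; beyond the scatter). Compound 3, `CC(=O)OCCOn1cnc2c(Cl)nc(I)nc21`, carries a different side chain on the same ring nitrogen, and in this assay compound 3 gives 11000 nM. Among the values shown, compound 2 stands highest of the two numbers, with compound 3 within the scatter of it.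

Compound 4, `CC(O)n1cnc2c(Cl)nc(I)nc21`, differs from compound 2 by hydrogen in place of acetyl on an oxygen on a saturated carbon. Among the measured compounds shown here, none of the measured steps changes the side chain: the single measured step, an at least 31-fold lower number from compound 1 to compound 2 (1.49 log units; beyond the scatter), sits on an aromatic carbon of the core, and the values of compound 2 and compound 3 only show that two different side chains on the ring nitrogen give numbers within the scatter of each other. For the measured compounds named here, no measured step therefore bears on the present change, and no step beyond the scatter is expected in this assay. Compound 4 is estimated at 20000 nM, with a range from 5000 nM to 80000 nM. This estimate means a step of a 1.3-fold higher number from compound 2 to compound 4 (0.10 log units; within the scatter), which is expected to stay within the scatter.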

Compound 4, half-maximal inhibitory concentration: > 500000 nM
Compound 4 was reported as a limit (the forecaster's own chance of this, stated with the estimate: 5%); middle value at least 25-fold (1.39 log units) from the limit.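

Until this point the only step beyond the scatter in this assay lay on an aromatic carbon of the core, and the side chain had shown no such step. Now an at least 31-fold higher number from compound 2 to compound 4 (1.49 log units; beyond the scatter) shows that acetoxy to hydroxy on the saturated carbon of the side chain can weigh as much in this series as the change on the core. In this assay compound 4 gives > 500000 nM which is a limit of the assay and not a number. Compound 2 keeps a measured number, whereas compound 1 and compound 4, each differing from it in one place, one on an aromatic carbon and one on the side chain, both stand at the limit: the limit of > 500000 nM in this assay, at which 2 of the 4 values shown sit.

The compounds shown leave open whether the acetyl itself is required on that oxygen, or whether a longer acyl chain such as butanoyl, or a methyl ether, would also keep a measured number. They also leave open whether the side chain of compound 3 would respond in the same way to loss of its acetyl, and what an amine in place of the acetoxy would give.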